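Swapping a benzyl for an ester chain on a triazole amide

The compounds below may be only part of what the source reports. "The series", "measured", "known", "first", "only" and "open" are said of these compounds alone.

In a functional assay on B16 cells (Mus musculus) for cytotoxicity, read by MTT assay, with a stated time of 48 h (a lower number here means a stronger inhibitor, a higher number a weaker inhibitor), compound 1 `CCOC(=O)Cn1cc(-c2cccc(NC(=O)c3cn(Cc4ccccc4)nn3)c2)nn1` gives 21000 nM. Compound 2 `CCOC(=O)Cn1cc(C(=O)Nc2cccc(-c3cn(CC(=O)OCC)nn3)c2)nn1` is the same molecule with one change: ethoxycarbonyl in place of phenyl on a saturated chain carbon bound to an aromatic nitrogen. For compound 2 this assay reports only a limit, > 100000 nM. The step that this change made is an at least 4.7-fold higher number from compound 1 to compound 2 (0.67 log units; beyond the scatter), the size being open-ended due to the limit of > 100000 nM in this assay, at which 1 of the 3 values shown sits. Compound 3 `O=C(Nc1ccccc1)c1cn(Cc2ccccc2)nn1` is a smaller relative, and in this assay compound 3 gives 93000 nM. The difference between the core of compound 3 and the core of compound 1 is not broken down here.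

Compound 4 `CCOC(=O)Cn1cc(C(=O)Nc2ccccc2)nn1` has not yet been measured. It differs from compound 3 by ethoxycarbonyl in place of phenyl on a saturated chain carbon bound to an aromatic nitrogen, which is the same change that turned compound 1 into compound 2. Since compound 3 already sits at the higher end of the measured values, a change that raised the number of compound 1 by an at least 4.7-fold higher number from compound 1 to compound 2 (0.67 log units; beyond the scatter) is expected to carry compound 4 past the reach of the measurement. The step from compound 3 to compound 4 is estimated at a 4.3-fold higher number from compound 3 to compound 4 (0.63 log units; beyond the scatter), resting on that single measured precedent. Compound 4 is therefore expected to give about 400000 nM in this assay, most likely reported only as a limit.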

Compound 4, half-maximal inhibitory concentration: > 100000 nM
Compound 4 was reported as a limit; the forecaster's own chance of this, stated with the estimate: 85%; the middle value is on the limit's open side.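

In this assay compound 4 gives > 100000 nM, which is a limit and not a number. The step this leaves is an at least 1.0-fold higher number from compound 3 to compound 4 (0.03 log units; that floor lies within the scatter), so on this smaller core the swap of phenyl for ethoxycarbonyl is not shown to raise the number, though the result does not speak against a rise either. Carrying the change from one core to the other is thus neither confirmed nor refuted, and whether it has the same size on both cores remains unknown: the same change on two cores in this assay, an at least 4.7-fold higher number (0.67 log units; beyond the scatter) from compound 1 to compound 2 and an at least 1.0-fold higher number (0.03 log units; that floor lies within the scatter) from compound 3 to compound 4; the limit leaves it open whether they differ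

The compounds shown carry only benzyl or (ethoxycarbonyl)methyl on the triazole nitrogen, which leaves open what a carboxylic acid or a longer chain in that place would do to the number in this assay. Any reading of the ester compounds also remains bounded by the top of the measured range: the limit of > 100000 nM in this assay, at which 2 of the 4 values shown sit.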